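The compounds below may be only part of what the source reports. "The series", "measured", "known", "first", "only" and "open" are said of these compounds alone.

Measured so far in a functional assay on HeLa cells (Homo sapiens) for cytotoxicity, read by MTT assay; a higher number here means a weaker inhibitor, a lower number a stronger inhibitor:

Compound 1, `COC(C)CO[C@H](CC=C(C)C)C1=CC(=O)c2c(O)ccc(O)c2C1=O`: 53400 nM
Compound 2, `CCCC(C)(O)CC(=O)O[C@H](CC=C(C)C)C1=CC(=O)c2c(O)ccc(O)c2C1=O`: 72000 nM
Compound 3, `CC(C)=CC[C@@H](OC(=O)C1CCCOC1)C1=CC(=O)c2c(O)ccc(O)c2C1=O`: 60500 nM

The three numbers sit close together. The steps of a 1.3-fold higher number from compound 1 to compound 2 (0.13 log units; within the scatter) and a 1.1-fold higher number from compound 1 to compound 3 (0.05 log units; within the scatter) both fall within the scatter, as does the step of a 1.2-fold lower number from compound 2 to compound 3 (0.08 log units; within the scatter); on the numbers shown, compound 1 stands level with compounds 2 and 3 rather than apart from them.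

Compound 4, `CCC(CO[C@H](CC=C(C)C)C1=CC(=O)c2c(O)ccc(O)c2C1=O)OC`, has not yet been measured in this assay. Relative to compound 1 the change is methyl in place of hydrogen on a saturated chain carbon, two bonds along the chain from an oxygen on a saturated carbon. The measured steps from compound 1 all concern the group on the oxygen on the saturated carbon, and replacing the 2-methoxypropyl group there by either (2-hydroxy-2-methylpentyl)carbonyl or (oxan-3-yl)carbonyl moved the number only within the scatter. Within the data shown here, no measured step adds a methyl on the chain itself, so the expectation rests on the general insensitivity of this assay to changes at that position. The step from compound 1 to compound 4 is therefore expected to be a 1.0-fold higher number from compound 1 to compound 4 (0.01 log units; within the scatter), with no direction beyond the scatter. For compound 4 the estimated value in this assay is 55000 nM, expected to lie between 25000 nM and 120000 nM.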

Compound 4, half-maximal inhibitory concentration: 63500 nM
Estimate against measurement, compound 4: 1.2-fold (0.06 log units) below, within the range that was stated.
By their numbers in this assay, from the lowest: compounds 1, 3, 4 and 2 (each within the scatter of the next).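

In this assay, among these compounds, the first change on the chain itself, methyl in place of hydrogen on a saturated chain carbon, two bonds along the chain from an oxygen on a saturated carbon, stays within the scatter (a 1.2-fold higher number from compound 1 to compound 4 (0.08 log units; within the scatter)). Compound 4, with its 2-methoxybutyl group, also stands level with the two compounds carrying a carbonyl group on that oxygen (a 1.0-fold higher number from compound 3 to compound 4 (0.02 log units; within the scatter); a 1.1-fold lower number from compound 2 to compound 4 (0.05 log units; within the scatter)), so the chain methyl does not set it apart from any compound shown. No measurement shown bears on why these numbers stay together.

As far as these compounds go, whether a longer chain, an amine or a carboxylic acid on this chain carbon would move the number beyond the scatter remains open. Equally open, from the compounds shown here alone, is whether changes to the shared core would do so.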